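A few compounds are considered here, and "the series" means these few. Any claim that something is new, unique, unknown or untested is made for them only; others in the source may bear on it.

In a functional assay, read by chemiluminescence (a higher number here means a weaker inhibitor, a lower number a stronger inhibitor), compound 1 (`COC(=O)CCC1CNc2cccc(O)c21`) gives 250 nM as its reading, compound 2 (`COC(=O)CCC1CN(C)c2cccc(O)c21`) has "not determined" (no result reported) as its entry, and compound 3 (`COC(=O)CCC1CNc2cc(O)ccc21`) gives 1380 nM as its reading. Compound 3 therefore holds the higher of the two available numbers, with a gap to compound 1 that lies beyond the scatter, making it the weaker inhibitor of that pair. Compound 4 (`O=C(O)CCC1CNc2cc(O)ccc21`) differs from compound 3 in one place (hydrogen in place of methyl on an oxygen next to a carbonyl group): hydrogen in place of methyl on an oxygen next to a carbonyl group, so methoxycarbonyl becomes carboxy. Among the compounds with values here, no measured pair shows this change, so the direction remains uncertain. The expected step of a 2.2-fold higher number from compound 3 to compound 4 (0.34 log units; beyond the scatter) in this assay is a moderate rise in the number, meaning weaker inhibition. Compound 4 is estimated at 3000 nM with a likely range from 500 nM to 18000 nM in this measurement.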

Compound 4, half-maximal inhibitory concentration: 1340 nM
The estimate for compound 4 lay 2.2-fold (0.35 log units) above the measured number; measured number inside the range.
By their numbers in this assay, from the lowest: compound 1; then compounds 4 and 3 (each within the scatter of the next).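

In this assay the swap of methoxycarbonyl for carboxy gives a 1.0-fold lower number from compound 3 to compound 4 (0.01 log units; within the scatter) and so shows that, on this core, the two groups cannot be told apart. Within the data shown here, this is the first reading of any change at this end of the side chain, since the earlier compounds all carry methoxycarbonyl. Nothing available explains why the two compounds read alike.

From the compounds shown here alone, whether carboxy would behave the same way on the core of compound 1 stays open. So does the effect of an amide or a longer chain at this end.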